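This account rests on a few compounds, and the source may have more. Where it says the series, first, only, none or still open, it means among the compounds named here.

Measured in a functional assay on SK-OV-3 cells (Homo sapiens) for cytotoxicity, read by MTT assay, with a stated time of 3 days; a lower number here means a stronger inhibitor, a higher number a weaker inhibitor:
- compound 1 `N#Cc1c(Cl)nc(SCc2nc3ccccc3[nH]2)nc1-c1ccccc1`: 3.37 nM
- compound 2 `CCNc1nc(SCc2nc3ccccc3[nH]2)nc(-c2ccccc2)c1C#N`: 7.35 nM
- compound 3 `N#Cc1c(NNC(N)=S)nc(SCc2nc3ccccc3[nH]2)nc1-c1ccccc1`: 3 nM

Compound 2 has the highest number of the three, so it is the weakest inhibitor here, though only modestly. Compound 4 `N#Cc1c(NC(N)=S)nc(SCc2nc3ccccc3[nH]2)nc1-c1ccccc1` differs from it in one place: a group of 3 heavy atoms (1 carbon, 1 nitrogen, 1 sulfur; no ring) in place of a group of 2 heavy atoms (2 carbon; no ring), on a nitrogen on an aromatic ring. The closest guide is a 2.5-fold lower number from compound 2 to compound 3 (0.39 log units; beyond the scatter), a modest step that also swaps the ethyl for a group containing sulfur. Also relevant is a 1.1-fold lower number from compound 1 to compound 3 (0.05 log units; within the scatter), which shows that such a group can match the chloro compound. A modest drop is therefore expected, of about a 2.1-fold lower number from compound 2 to compound 4 (0.32 log units; beyond the scatter). For compound 4 the estimated value is 3.5 nM, with an expected range of 1.5 nM to 8 nM.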

Compound 4, half-maximal inhibitory concentration: 7.81 nM
Compound 4: middle estimate off by 2.2-fold (0.35 log units), on the low side; low and high end bracket the measured number.
By their numbers in this assay, from the lowest: compounds 3 and 1 (each within the scatter of the next); then compounds 2 and 4 (each within the scatter of the next).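

In this assay the step is a 1.1-fold higher number from compound 2 to compound 4 (0.03 log units; within the scatter) when ethyl gives way to the sulfur-bearing group of compound 4, so carrying sulfur on that nitrogen does not by itself lower the number. Shortening that sulfur-bearing group from 4 heavy atoms to 3 gives a 2.6-fold higher number from compound 3 to compound 4 (0.42 log units; beyond the scatter) and the shorter group also falls short of the chloro compound, with a 2.3-fold higher number from compound 1 to compound 4 (0.37 log units; beyond the scatter) as the step.

From the compounds shown here alone, whether a longer chain such as butyl on that nitrogen would move the number further stays open. Nothing shown explains why these small changes shift the number.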